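Swapping Dichlorophenyl for Fluorophenyl on a Shared Core

The source may report more compounds than this note shows. Statements on the series, on what has been measured and on what is new or still open speak of the compounds shown alone.

Of the compounds shown here, three with a shared core have been tested in a functional assay on mitochondria from heart for inhibition of peroxisomal acyl-coenzyme A oxidase 1 (Rattus norvegicus); a higher number here means a weaker inhibitor, a lower number a stronger inhibitor. Compound 1 `Cc1nc2cc(OC[C@H](O)CN3CCN(Cc4nc(-c5ccc(C(C)C)cc5)no4)CC3)ccc2s1` gives 1230 nM, compound 2 `Cc1nc2cc(OC[C@H](O)CN3CCN(Cc4coc(-c5ccc(C(F)(F)F)cc5)n4)CC3)ccc2s1` gives 11000 nM, and compound 3 `Cc1nc2cc(OC[C@H](O)CN3CCN(Cc4noc(-c5ccc(Cl)c(Cl)c5)n4)CC3)ccc2s1` gives 550 nM. Compound 3 is therefore the strongest inhibitor of the three, its gaps to compound 1 and compound 2 both lying beyond the usual scatter. Compound 4 `Cc1nc2cc(OC[C@H](O)CN3CCN(Cc4noc(-c5cccc(F)c5)n4)CC3)ccc2s1` awaits measurement and differs from compound 3 in one place: 3-fluorophenyl in place of 3,4-dichlorophenyl on an aromatic carbon. For the measured compounds named here, no measured pair shows this exact change, so the expectation rests only on the other compounds, which all gave higher numbers than compound 3. A weakening step is expected, of about a 3.6-fold higher number from compound 3 to compound 4 (0.56 log units; beyond the scatter). Compound 4 is estimated at 2000 nM, within a likely range from 700 nM to 6000 nM.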

Compound 4, half-maximal inhibitory concentration: 13400 nM
The estimate for compound 4 lay 6.7-fold (0.83 log units) below the measured number, and the stated range ends below it.
By their numbers in this assay, from the lowest: compound 3; then compound 1; then compounds 2 and 4 (each within the scatter of the next).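

In this assay this position on the five-membered ring proves highly sensitive, as 3-fluorophenyl in place of 3,4-dichlorophenyl gives a 24-fold higher number from compound 3 to compound 4 (1.39 log units; beyond the scatter) in the only single-place comparison shown. The aryl group here can therefore separate a stronger inhibitor from a much weaker one on an unchanged core. No measurement at hand explains this step. The change swaps the halogen and also leaves one fewer halogen on the ring, and these two parts remain unseparated. A phenyl ring carrying one chlorine would help to tell them apart, while a methoxy group would test a non-halogen substituent here.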